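The compounds below may be only part of what the source reports. "The series", "measured", "known", "first", "only" and "open" are said of these compounds alone.

Measured compounds:
- compound 1, `CCOC(=O)c1cc(-c2ccc(OCC)cc2)ccn1`, which in an assay on COS-7 cells for inhibition of patatin-like phospholipase domain-containing protein 2 (Mus musculus) (on this read-out higher numbers stand for weaker inhibition and lower numbers for stronger inhibition), gives 105000 nM
- compound 2, `CN(C)c1ccc(-c2cccc(N)c2)cc1`, which in this assay gives 100000 nM

Both numbers are very high, so neither compound inhibits the enzyme to any useful degree. Compound 2 has the lower of the two numbers, but its gap to compound 1 is within the scatter, so the two compounds cannot be told apart on this read-out.

Compound 3, `CN(C)c1ccc(-c2cccc(NC(=O)N3CCOCC3)c2)cc1`, is the next compound and has not yet been measured in this assay. It is built from compound 2 by a single change: (morpholin-4-yl)carbonyl in place of hydrogen on a nitrogen on an aromatic ring. The amine of compound 2 thus becomes a urea that carries a saturated six-membered ring.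

Going by the values given here, no pair of measured compounds shows what this change does, so its effect cannot be read from the data. Only the weak starting point of compound 2 is known. The expectation here is that the step from compound 2 to compound 3 lowers the number, that is, strengthens inhibition, by a 20-fold lower number from compound 2 to compound 3 (1.30 log units; beyond the scatter), more than the scatter alone. From the compounds shown here alone, compound 3 is therefore expected to give an estimated 5000 nM, with a broad range from 500 nM to 60000 nM, since the change is untested.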

Compound 3, half-maximal inhibitory concentration: > 200000 nM
Compound 3: only a limit was reported (the forecaster's own chance of this, stated with the estimate: 15%); middle value at least 40-fold (1.60 log units) away from the limit.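

In this assay compound 3 gives > 200000 nM, which is a limit of the assay and not a number. Going by these compounds alone, this is the first view of a change at the nitrogen on the aromatic ring, and it shows that turning the amine of compound 2 into a urea with a (morpholin-4-yl)carbonyl group brings no gain in inhibition: the data give an at least 2.0-fold higher number from compound 2 to compound 3 (0.30 log units; that floor lies within the scatter). That figure is only a floor, so the change may cost little or a great deal, and a real loss cannot be claimed from this pair alone, as the reading rests on a single limit: the limit of > 200000 nM in this assay, at which 1 of the 3 values shown sits.

From the compounds shown here alone, what a smaller group on this same nitrogen would do stays open, for example an acetyl group, or a urea ending in a simple dimethylamino group in place of the saturated ring. Going by these compounds, it also stays open whether a change elsewhere on the shared core, such as replacing the dimethylamino group of compound 2 with a carboxylic acid, could bring the numbers down to a useful range.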